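Trimming a Chain: From Compound 2 to Compound 4

The source may report more compounds than this note shows. Statements on the series, on what has been measured and on what is new or still open speak of the compounds shown alone.

Of the compounds shown here, three built on a shared core have been tested in a functional assay on the whole organism (Tail, strain ICR) with Mus musculus as the target, in the tail flick test, with a stated time of 150 min, at a dose of 25 umol/kg by the oral route; a higher number here means a stronger effect of the compound at the dose given, a lower number a weaker effect. Compound 1 `O=C(CN(c1nc(Cl)nc2[nH]cnc12)C1CC1)NCC(=O)OCc1ccccc1` gives 18%, compound 3 `C[C@@H](O)[C@H](NC(=O)CN(c1nc(Cl)nc2[nH]cnc12)C1CC1)C(=O)O` gives 24%, and compound 2 `O=C(CN(c1ncnc2c1ncn2C1CCCCO1)C1CC1)N[C@@H](CCC(=O)OCc1ccccc1)C(=O)OCc1ccccc1` gives 14.1%. Compound 2 carries the smallest of the three numbers, yet both compound 1 and compound 3 lie within the usual scatter of it, so the three results cannot be told apart with confidence.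

Compound 4 `C[C@H](NC(=O)CN(c1ncnc2c1ncn2C1CCCCO1)C1CC1)C(=O)OCc1ccccc1` is compound 2 with one change: hydrogen in place of (benzyloxycarbonyl)methyl on a saturated chain carbon, two bonds along the chain from an amide-type nitrogen and a carbonyl carbon. Cut one bond further out, the same change reads 2-(benzyloxycarbonyl)ethyl to methyl. Going by the values given here, no pair of measured compounds differs in just this way, so there is no measured step to lean on.

With the three measured results sitting so close together, the step from compound 2 to compound 4 is expected to be a number 3.9 percentage points higher from compound 2 to compound 4 (within the scatter), that is, no change beyond the scatter. Compound 4 is therefore estimated at 18%, with a plausible range from 8% to 30%.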

Compound 4, a percentage reported as activity, at one dose (the size of the read-out at that dose, not a potency): 6.01%
Compound 4: middle estimate off by 12 percentage points, on the high side, outside the stated range (below it).
By their numbers in this assay, from the lowest: compounds 4, 2, 1 and 3 (each within the scatter of the next, the first and the last beyond it).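

In this assay, this first pair of measured compounds differing in one place gives a number 8.1 percentage points lower from compound 2 to compound 4 (within the scatter). On this saturated chain carbon, two bonds along the chain from an amide-type nitrogen and a carbonyl carbon, a group of 11 heavy atoms including an aromatic ring can therefore give way to hydrogen without a change that stands clear of the scatter, although one pair at a single dose is thin support. No measurement here offers an explanation for this result.

As far as these compounds go, whether a carboxylic acid, an amine or a longer carbon chain in place of (benzyloxycarbonyl)methyl on this carbon would give a step beyond the scatter stays open. From the compounds shown here alone, whether the same exchange would give a similar step on the core of compound 1 also stays open.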